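The source may report more compounds than this note shows. Statements on the series, on what has been measured and on what is new or still open speak of the compounds shown alone.

Measured in a functional assay on MCF7 cells (Homo sapiens) for cytotoxicity, read by CellTiter-Glo, with a stated time of 5 days; a lower number here means a stronger inhibitor, a higher number a weaker inhibitor:
compound 1 `CC/C(=C(/c1ccc(/C=C/C(=O)O)cc1)c1ccc2[nH]ncc2c1)c1ccccc1`: 7.2 nM
compound 2 `O=C(O)/C=C/c1ccc(/C(=C(\c2ccccc2)C2CCCC2)c2ccc3[nH]ncc3c2)cc1`: 10 nM
compound 3 `O=C(O)/C=C/c1ccc(/C(=C(\c2ccccc2)C2CCCCC2)c2ccc3[nH]ncc3c2)cc1`: 64 nM

Compound 1 gives the lowest number of the three. Its step to compound 2, a 1.4-fold higher number from compound 1 to compound 2 (0.14 log units; within the scatter), stays within the scatter, while its step to compound 3, an 8.9-fold higher number from compound 1 to compound 3 (0.95 log units; beyond the scatter), lies beyond it; between the two cycloalkyl compounds the step is a 6.4-fold higher number from compound 2 to compound 3 (0.81 log units; beyond the scatter).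

Compound 4 `CC/C(=C(/c1ccc(/C=C/C(=O)O)cc1)c1ccc2[nH]ncc2c1C)c1ccccc1` differs from compound 1 by methyl in place of hydrogen on an aromatic carbon, ortho to a fused ring and ortho to a large group, so that 1H-indazol-5-yl becomes 4-methyl-1H-indazol-5-yl. Among the measured compounds shown here, none of the measured steps touches this position; all of them vary the group on the double-bonded chain carbon. For the measured compounds named here, there is therefore no measured step that bears on this change, and no shift beyond the scatter is expected in this assay.

Compound 4 is estimated at 10 nM, with a range of 3 nM to 35 nM, an expected step of a 1.4-fold higher number from compound 1 to compound 4 (0.14 log units; within the scatter).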

Compound 4, half-maximal inhibitory concentration: 50 nM
Estimate against measurement, compound 4: 5.0-fold (0.70 log units) below; the measured number lies above the stated range.
By their numbers in this assay, from the lowest: compounds 1 and 2 (each within the scatter of the next); then compounds 4 and 3 (each within the scatter of the next).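

In this assay the single added methyl gives a 6.9-fold higher number from compound 1 to compound 4 (0.84 log units; beyond the scatter) and so shows that this aromatic carbon, ortho to a fused ring and ortho to a large group, does not tolerate every change without a shift in the number. The earlier compounds shown here varied only the group on the double-bonded chain carbon, whereas here one heavy atom on the 1H-indazol-5-yl group moves the number beyond the scatter. Nothing available accounts for this shift.

From the compounds shown here alone, whether fluorine, chlorine or a methoxy group on this carbon would give a similar step remains open. So does whether the methyl would give the same step alongside the cyclopentyl group of compound 2.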